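The source may report more compounds than this note shows. Statements on the series, on what has been measured and on what is new or still open speak of the compounds shown alone.

Compound 1 (`COc1ccc(-c2c(C)nc3c(N4CC[C@@H](NC(C)=O)C4)cc(C)nn23)cc1OC`) is the starting point of this account. In an ADME assay on microsomes from liver (Mus musculus) for metabolic stability, read by LC-MS, with NADPH named in the record, with a stated time of 60 min, tested at 1 uM, in the absence of a further agent (a lower number here means that less of the compound is left, a higher number that more of the compound is left), compound 1 gives > 95% as a limit of the assay and not a number. Compound 2 (`COc1ccc(-c2c(C)oc3c(N4CC[C@@H](NC(C)=O)C4)cc(C)nc23)cc1OC`) gives > 95% in this assay as a limit too. Compound 3 (`COc1ccc(-c2scc3c(N4CC[C@@H](NC(C)=O)C4)nc(C)nc23)cc1OC`) gives > 95% in this assay as a limit too. The three measured compounds therefore stand together (the limit of > 95% in this assay, at which 3 of the 3 values shown sit) and the standing of compound 1 among them cannot be told more finely. All three carry the 3,4-dimethoxyphenyl group, and none carries thiophen-2-yl.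

Compound 4 (`CC(=O)N[C@@H]1CCN(c2cc(C)nn3c(-c4cccs4)c(C)nc23)C1`) keeps the core of compound 1 and changes one group, with thiophen-2-yl in place of 3,4-dimethoxyphenyl on an aromatic carbon. For the measured compounds named here, no measured pair shows what this exchange does, so any expectation is loose. Resting on compound 1 (> 95% as a limit) a modest fall in this assay is expected. The step expected is a number at least 7 percentage points lower from compound 1 to compound 4 (that floor lies within the scatter) and it may well stay within the usual scatter. For compound 4 the estimated value is 88% with an expected range from 65% to 100% in this measurement.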

Compound 4, percent of the compound remaining: > 95%
Compound 4 ended at the assay's limit (the forecaster's own chance of this, stated with the estimate: 45%); middle value at least 7 percentage points from the limit.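

In this assay compound 4 gives > 95%, a limit of the assay and not a number. For the compounds shown here, compound 1 also stands at a limit, so no step from compound 1 to compound 4 can be read. The compounds shown leave open what thiophen-2-yl in place of 3,4-dimethoxyphenyl does to the compound remaining, with every value at one limit: the limit of > 95% in this assay, at which 4 of the 4 values shown sit.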